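This account rests on a few compounds, and the source may have more. Where it says the series, first, only, none or still open, it means among the compounds named here.

Three compounds have been measured:

Compound 1 `S=C(N/N=C/c1ccc(Oc2ccc3ccccc3c2)cc1)Nc1ccccc1`: 6.07
Compound 2 `S=C(N/N=C/c1ccc(Oc2ccc(Cl)cc2)cc1)Nc1ccccc1`: 5.52
Compound 3 `Cc1ccc(Oc2ccc(/C=N/NC(=S)Nc3ccc(Br)cc3)cc2)cc1`: 6.17

In a physicochemical assay for lipophilicity, in phosphate buffer, measured as octanol-water partition, with a stated time of 24 h (on this read-out higher numbers stand for higher lipophilicity and lower numbers for lower lipophilicity), compound 2 stands lowest of the three. Compound 1 lies above it by a gap beyond the scatter, and compound 3 lies higher still, also beyond the scatter. Going by the values given here, none of these three pairs differs in a single place, so no step between measured compounds can be read off; the values only show that compound 2 sits at the bottom of this small set.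

Compound 4 `Fc1ccc(Oc2ccc(/C=N/NC(=S)Nc3ccccc3)cc2)cc1` has not yet been measured in this assay. It differs from compound 2 in one place: fluoro in place of chloro on an aromatic carbon. With no measured step of this kind in the set, the expectation rests on the change itself. The step from compound 2 to compound 4 is expected to be downward and beyond the scatter, a number 0.52 log units lower from compound 2 to compound 4 (beyond the scatter). Compound 4 is therefore estimated at 5 in this assay, with a range from 4.6 to 5.5.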

Compound 4, partition coefficient: 5.09
Estimate against measurement, compound 4: 0.09 log units below; the measured number falls inside the stated range.
By their numbers in this assay, from the lowest: compound 4; then compound 2; then compounds 1 and 3 (each within the scatter of the next).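

In this assay, going by these compounds alone, fluoro in place of chloro on an aromatic carbon, para to a large group, gives a number 0.43 log units lower from compound 2 to compound 4 (beyond the scatter) and this is the first step in the set that can be read at a single place. Within the data shown here, the earlier compounds differed from one another in more than one place, so only this pair shows that an exchange of one halogen for another at this position moves the number by more than the scatter. Nothing available explains the direction or the size of this step.

The compounds shown leave open how an amine, a carboxylic acid or a methoxy group would read at the same position on the shared core. They also leave open whether the same exchange gives a similar step when the other aromatic ring carries a bromo group.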